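Cyclobutyl for Isobutyl: Cytotoxicity Expected to Stay Low

A few compounds are considered here, and "the series" means these few. Any claim that something is new, unique, unknown or untested is made for them only; others in the source may bear on it.

This piece looks at an ADME assay on Huh-7 cells (Homo sapiens) for cytotoxicity, with a stated time of 72 h; on this read-out lower numbers stand for higher toxicity in this test and higher numbers for lower toxicity in this test. Compound 2 `CC(C)CCN1C(=O)C(C2=NS(=O)(=O)c3cc(NS(C)(=O)=O)ccc3N2)=C(O)C2CCCC21` gives > 1000 nM in this assay, which is a limit of the measurement and not a number. Compound 3 `CC(C)CCN1C(=O)C(C2=NS(=O)(=O)c3cc(NS(C)(=O)=O)ccc3N2)=C(O)[C@H]2CCC[C@H]21` gives > 1000 nM, again a limit. Compound 1 `CS(=O)(=O)Nc1ccc2c(c1)S(=O)(=O)N=C(C1=C(O)C3CCCCCCC3N(Cc3ccc(F)cc3)C1=O)N2` gives > 33000 nM, also a limit. Going by the values given here, the only step between compounds that differ in one place is a step that the two limits leave unreadable from compound 2 to compound 3, which cannot be sized because the limit of > 1000 nM in this assay, at which 2 of the 3 values shown sit, hides any difference, while the fact that one of compounds 2 and 3 is drawn with a defined configuration and the other without, at the place where they differ shows the two structures differ only in drawn configuration. Compound 4 `CS(=O)(=O)Nc1ccc2c(c1)S(=O)(=O)N=C(C1=C(O)C3CCCC3N(CC3CCC3)C1=O)N2` carries the change (cyclobutyl in place of isobutyl on a saturated chain carbon bound to an amide-type nitrogen in a ring). Among the compounds with values here, no measured step involves this kind of change, and every value so far is a limit, so the measured steps give no size to expect. The step that the limit leaves unreadable from compound 2 to compound 4 is therefore expected to be none beyond the scatter, with low toxicity kept. Compound 4 is estimated at 10000 nM, in a range from 1500 nM to 60000 nM.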

Compound 4, half-maximal cytotoxic concentration: > 33000 nM
Compound 4: a limit, no number (the forecaster's own chance of this, stated with the estimate: 75%); middle value at least 3.3-fold (0.51 log units) from the limit.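

Compound 2 and compound 4 both stand as limits of the measurement and not as numbers, and the step between them cannot be read. The compounds shown leave open whether cyclobutyl in place of isobutyl changes the result in this assay at all, and in which direction.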